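This account rests on a few compounds, and the source may have more. Where it says the series, first, only, none or still open, it means among the compounds named here.

Measured compounds:
compound 1 `CCCOC1=C(CCC)C(=O)/C(=C(O)/C=C/c2ccccc2)C(=O)C1(CCC)CCC` — 2 uM
compound 2 `CCCC1(CC=C(C)C)C(=O)C(C(=O)/C=C/c2ccccc2)=C(O)C(CCC)(CCC)C1=O` — "not determined" (no result reported)
compound 3 `CCCC1=C(OC)C(CCC)(CCC)C(=O)/C(=C(O)\C=C\c2ccc(I)cc2)C1=O` — 1.8 uM

In a functional assay on 1A9 cells (Homo sapiens) for antiproliferative activity, read by sulforhodamine B assay, with a stated time of 3 days (on this read-out higher numbers stand for an effect only at larger amounts of compound and lower numbers for an effect already at smaller amounts), compound 1 gives 2 uM and compound 3 gives 1.8 uM; the two numbers lie within the scatter of each other, so neither can be set above the other. Compound 2 has no number in this assay.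

Compound 4 `CCCC1=C(OCC)C(CCC)(CCC)C(=O)/C(=C(O)\C=C\c2ccccc2)C1=O` differs from compound 1 only in the alkoxy chain: hydrogen in place of methyl on a saturated chain carbon, two bonds along the chain from an oxygen on an unsaturated carbon. A single carbon leaves a saturated chain and nothing else moves. Within the data shown here, no step between measured compounds isolates this change, so the expectation rests on the size of the difference alone. No step beyond the scatter is expected for compound 4 in this assay, and the step of no change at the digits printed from compound 1 to compound 4 (within the scatter) is taken as essentially flat. Compound 4 is therefore estimated at 2 uM, with a range of 1 uM to 4 uM.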

Compound 4, concentration for half-maximal effect: 4.3 uM
For compound 4 the middle estimate is 2.2-fold (0.33 log units) below the measured one; measured number outside the range, above it.
By their numbers in this assay, from the lowest: compounds 3 and 1 (each within the scatter of the next); then compound 4.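

In this assay, going from propoxy to ethoxy on the shared core gives a 2.2-fold higher number from compound 1 to compound 4 (0.33 log units; beyond the scatter). Among these compounds, this is the first pair that differs in one place, and it shows that removing a single carbon from the saturated alkoxy chain registers at this position, though only modestly. Nothing measured here bears on the reason for this step.

One step gives a direction for this single change, not a trend with chain length. Going by these compounds, a butoxy chain or an amine at this place remains open, as does whether the same change reads alike with an iodine on the phenyl ring.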